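Amino for chloro on the core of compound 2

This account rests on a few compounds, and the source may have more. Where it says the series, first, only, none or still open, it means among the compounds named here.

Measured so far:
compound 1, `Nc1nn(C(=O)Nc2ccc(Cc3ccccc3)cc2)c2ccccc12` — in a functional assay on NCI-H226 cells (Homo sapiens) for antiproliferative activity, read by sulforhodamine B assay, with a stated time of 48 h (a higher number here means a weaker inhibitor of growth, a lower number a stronger inhibitor of growth), compound 1 gives 58200 nM
compound 2, `Nc1nn(C(=O)Nc2ccc(Cc3ccccc3)cc2)c2ccc(Cl)cc12` — in this assay compound 2 gives 66700 nM

Compound 2 has the higher of the two numbers in this assay, but its step from compound 1 is a 1.1-fold higher number from compound 1 to compound 2 (0.06 log units; within the scatter), so the two compounds cannot be ordered on these data. Among the compounds with values here, the only change studied so far is chloro in place of hydrogen on an aromatic carbon of the shared core, and it moved the number by less than the scatter.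

Compound 3, `Nc1ccc2c(c1)c(N)nn2C(=O)Nc1ccc(Cc2ccccc2)cc1`, is not yet measured in this assay. It differs from compound 2 in one place: amino in place of chloro on an aromatic carbon. Within the data shown here, no measured pair shows an amino group entering at this point of the core, so the one step available, the one from compound 1 to compound 2, bears on it only in that substitution at this carbon has so far left the number where it was. Among the measured compounds shown here, with a single within-scatter precedent and no direct analogue, the expectation is no step beyond the scatter, a change of about a 1.1-fold lower number from compound 2 to compound 3 (0.05 log units; within the scatter). Compound 3 is therefore estimated at 60000 nM in this assay, within a range of 20000 nM to 180000 nM.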

Compound 3, concentration for total growth inhibition: 38300 nM
Beside the measured number, compound 3's estimate is 1.6-fold (0.19 log units) above it, within the range that was stated.
By their numbers in this assay, from the lowest: compounds 3, 1 and 2 (each within the scatter of the next).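

In this assay, amino on this aromatic carbon of the shared core gives a 1.7-fold lower number from compound 2 to compound 3 (0.24 log units; within the scatter) when it takes the place of chloro, and a 1.5-fold lower number from compound 1 to compound 3 (0.18 log units; within the scatter) when it takes the place of hydrogen. This carbon has now carried hydrogen, chloro and amino, and even the exchange of chloro for amino, which adds a hydrogen-bond donor and a hydrogen-bond acceptor, leaves the two compounds inside the scatter of each other, so no group can be ranked above another at this position on these data. Nothing at hand bears on why the numbers fall as they do.

The compounds shown leave open whether any group on this carbon can move the number beyond the scatter, for instance a carboxylic acid, a methoxy group or a longer chain ending in an amine. They also leave open whether the same insensitivity holds at the other carbons of the shared core, or when the rest of the structure around this position is changed.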